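The source may report more compounds than this note shows. Statements on the series, on what has been measured and on what is new or still open speak of the compounds shown alone.

Compound 1 `Nc1sc(-c2ccc(Cl)cc2)c(-c2ccc(Cl)cc2)c1C(=O)NC1CCC1` carries the shared core with a cyclobutylamino group on the carbonyl carbon. In a functional assay on PC-3 cells (Homo sapiens) for inhibition, read by sulforhodamine B assay, with a stated time of 72 h (on this read-out lower numbers stand for stronger inhibition and higher numbers for weaker inhibition), compound 1 gives 24800 nM, the highest of the three numbers recorded. Compound 2 `Nc1sc(-c2ccc(Cl)cc2)c(-c2ccc(Cl)cc2)c1C(=O)N1CCOCC1` gives 11700 nM in this assay, and compound 3 `CCCCNC(=O)c1c(N)sc(-c2ccc(Cl)cc2)c1-c1ccc(Cl)cc1` gives 17800 nM in this assay. The change on the carbonyl carbon lowered the number a 2.1-fold lower number from compound 1 to compound 2 (0.33 log units; beyond the scatter), whereas the exchange on the amide-type nitrogen gave a 1.4-fold lower number from compound 1 to compound 3 (0.14 log units; within the scatter) and the further exchange on the carbonyl carbon gave a 1.5-fold higher number from compound 2 to compound 3 (0.18 log units; within the scatter).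

Compound 4 `Nc1sc(-c2ccc(Cl)cc2)c(-c2ccc(Cl)cc2)c1C(=O)N1CCNCC1` differs from compound 1 by piperazin-1-yl in place of cyclobutylamino on a carbonyl carbon. Among the measured compounds shown here, the step bearing most directly on this is the one to compound 2, where a six-membered ring with two hetero atoms replaced cyclobutylamino on the same carbonyl carbon and gave a 2.1-fold lower number from compound 1 to compound 2 (0.33 log units; beyond the scatter). Compound 4 is therefore expected to show a modest lowering of the same size, a 2.1-fold lower number from compound 1 to compound 4 (0.32 log units; beyond the scatter). The estimate for compound 4 in this assay is 12000 nM, with a range from 5000 nM to 30000 nM.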

Compound 4, half-maximal inhibitory concentration: 2710 nM
Compound 4: the middle estimate sits 4.4-fold (0.65 log units) above what was measured, outside the stated range (below it).
By their numbers in this assay, from the lowest: compound 4; then compounds 2, 3 and 1 (each within the scatter of the next, the first and the last beyond it).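

In this assay the group on the carbonyl carbon proves able to move the number much further than the first three compounds showed: piperazin-1-yl gives a 9.2-fold lower number from compound 1 to compound 4 (0.96 log units; beyond the scatter) and a 6.6-fold lower number from compound 3 to compound 4 (0.82 log units; beyond the scatter) at the same place. Ring size alone does not settle the matter: morpholin-4-yl and piperazin-1-yl are both six-membered rings, yet the change from one to the other gives a 4.3-fold lower number from compound 2 to compound 4 (0.64 log units; beyond the scatter) with a ring nitrogen standing where the ring oxygen stood. Nothing available explains why this single exchange has such an effect. The compounds shown leave open whether the hydrogen on that ring nitrogen matters, which a methyl or acetyl group placed there would test. They also leave open whether a piperidine ring, with carbon at that ring position, would behave like either of the two rings.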